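Three naphthyl trimethoxyphenyl analogues and a phenolic replacement

The source may report more compounds than this note shows. Statements on the series, on what has been measured and on what is new or still open speak of the compounds shown alone.

Measured compounds:
compound 1 `CCOC(=O)CCO/N=C(/c1ccc(OC)c(OC)c1OC)c1cccc2ccccc12` — 10000 nM
compound 2 `COc1ccc(C(O)(Cc2ccc(C)cc2)c2cccc3ccccc23)c(OC)c1OC` — > 20000 nM (a limit of the assay)
compound 3 `COc1ccc(C(OCc2ccccc2)c2cccc3ccccc23)c(OC)c1OC` — > 20000 nM (a limit of the assay)

All three were tested in a functional assay on HCT-116 cells (Homo sapiens) for inhibition, read by sulforhodamine B assay, with a stated time of 48 h; on this read-out lower numbers stand for stronger inhibition and higher numbers for weaker inhibition. Compound 1 gives 10000 nM in this assay. For compound 2 only a limit is reported, > 20000 nM. Compound 3 likewise returns only a limit, > 20000 nM, so it stands at the weak end of what the set shows. Among the compounds with values here, the set carries two such limits, as the limit of > 20000 nM in this assay, at which 2 of the 3 values shown sit, records, and no pair of measured compounds differs in a single place, so no step size can be read from the data.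

The unmeasured compound 4 `COc1ccc(C(c2ccccc2O)c2cccc3ccccc23)c(OC)c1OC` is reached from compound 3 by one change: 2-hydroxyphenyl in place of benzyloxy on a saturated chain carbon bound to two aromatic carbons. Both the departing and the entering groups are single aromatic rings attached at the same chain carbon; the difference the count shows is the hydroxyl donor that enters.

Within the data shown here, with no measured step to lean on, compound 4 is expected to remain weak, with an estimated step from compound 3 to compound 4 of an at least 1.6-fold lower number from compound 3 to compound 4 (0.22 log units; that floor lies within the scatter), most likely within the scatter. Compound 4 is estimated at 12000 nM in this assay, with a range from 3000 nM to 40000 nM, and a real chance that only a limit is returned again.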

Compound 4, half-maximal inhibitory concentration: > 20000 nM
Compound 4: only a limit was reported; the forecaster's own chance of this, stated with the estimate: 50%; at least 1.6-fold (0.22 log units) between middle value and limit.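

In this assay compound 4 returns > 20000 nM which is a limit of the assay. No step can be read between compound 3 and compound 4, because both results are limits: the limit of > 20000 nM in this assay, at which 3 of the 4 values shown sit.

The compounds shown leave open whether 2-hydroxyphenyl or benzyloxy on a saturated chain carbon bound to two aromatic carbons gives the lower number, and how far past the limit either compound lies.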